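Pyrazole for difluorophenyl on the thiazole acetic acid series

The source may report more compounds than this note shows. Statements on the series, on what has been measured and on what is new or still open speak of the compounds shown alone.

In an in vitro functional assay on HEK285-7 cells for antagonist activity at prostaglandin D2 receptor 2 (Homo sapiens), read by BRET and beta-arrestin recruitment (on this read-out higher numbers stand for weaker inhibition and lower numbers for stronger inhibition), compound 1 `O=C(O)Cc1sc(C(c2ccccc2)c2ccccc2)nc1-c1cccc(F)c1` gives 29 nM. Within the data shown here, compound 2 `O=C(O)Cc1sc(C(c2ccc(F)cc2)c2ccc(F)cc2)nc1-c1cc(F)cc(F)c1` carries fluorine on all three phenyl rings and, in this assay, compound 2 gives 340 nM, the highest of the two numbers measured so far; against compound 1 the gap is beyond the scatter, so compound 2 is the weaker of the pair as measured.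

Compound 3 `O=C(O)Cc1sc(C(c2ccc(F)cc2)c2ccc(F)cc2)nc1-c1cn[nH]c1` keeps the bis(4-fluorophenyl)methyl group and changes only the ring on the core: 1H-pyrazol-4-yl in place of 3,5-difluorophenyl on an aromatic carbon. Among the measured compounds shown here, no measured pair shows this kind of exchange, so nothing sets its size or direction. The estimate for compound 3 in this assay is a step of a 1.8-fold higher number from compound 2 to compound 3 (0.25 log units; within the scatter), leaning toward a somewhat higher number but with wide uncertainty, so an outcome within the scatter is also plausible. Compound 3 is therefore expected to give about 600 nM, with a range from 150 nM to 2500 nM.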

Compound 3, half-maximal inhibitory concentration: 220 nM
The estimate for compound 3 lay 2.7-fold (0.44 log units) above the measured number; low and high end bracket the measured number.
By their numbers in this assay, from the lowest: compound 1; then compounds 3 and 2 (each within the scatter of the next).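

In this assay, the core position next to the ring nitrogen accepts 1H-pyrazol-4-yl in place of 3,5-difluorophenyl with a 1.5-fold lower number from compound 2 to compound 3 (0.19 log units; within the scatter), so this pair cannot be separated on this read-out. Among these compounds, this is the first exchange read at this position, and a five-membered aromatic ring with 2 hetero atoms, 1 hydrogen-bond donor and 1 hydrogen-bond acceptor reads alike with a six-membered all-carbon aromatic ring that has neither donor nor acceptor. No measurement at hand explains this match.

Open, going by these compounds, is whether the hydrogen on the pyrazole nitrogen contributes, which 1-methyl-1H-pyrazol-4-yl at the same position would address. Also open, on these data alone, is how far the position tolerates other groups, such as a pyridin-3-yl ring, a morpholine ring or a primary amine.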